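This account rests on a few compounds, and the source may have more. Where it says the series, first, only, none or still open, it means among the compounds named here.

Three measured compounds share a pyrazole-linked enone framework and were tested in a functional assay on OVCAR-3 cells (Homo sapiens) for inhibition, read by sulforhodamine B assay, with a stated time of 48 h; a higher number here means a weaker inhibitor of growth, a lower number a stronger inhibitor of growth. Compound 1 `COc1ccc(-c2cc(/C=C/C(=O)c3ccc(N)cc3)[nH]n2)cc1` gives 1250 nM in this assay. Compound 2 `COc1ccc(-c2cc(/C=C/C(=O)c3ccc(N)cc3)[nH]n2)cc1OC` gives 1920 nM, and compound 3 `COc1cc(C(=O)/C=C/c2cc(-c3cc(OC)c(OC)c(OC)c3)n[nH]2)cc(OC)c1OC` gives 1750 nM; the three numbers lie within the scatter of one another. Compound 2 and compound 1 differ in one place, (hydrogen in place of methoxy on an aromatic carbon), and the step of a 1.5-fold lower number from compound 2 to compound 1 (0.19 log units; within the scatter) is within the scatter. Compound 4 `COc1ccc(-c2cc(/C=C/C(=O)c3cc(OC)c(OC)c(OC)c3)[nH]n2)cc1OC` is not yet measured. It differs from compound 3 in one place, (hydrogen in place of methoxy on an aromatic carbon). This is the same kind of change as that from compound 2 to compound 1, though not the same: around the place in compound 3 the carbon also sits meta to a methoxy group, which is not the case in compound 2. How the core of compound 3 differs from that of compound 2 is not broken down here. Resting on the step from compound 2 to compound 1, the expected step of a 1.3-fold lower number from compound 3 to compound 4 (0.13 log units; within the scatter) is small. Compound 4 is therefore estimated at 1300 nM, within 600 nM to 3000 nM.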

Compound 4, concentration for 50% growth inhibition: 1590 nM
Compound 4: middle estimate off by 1.2-fold (0.09 log units), on the low side, and the stated range covers the measured number.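

In this assay, putting hydrogen in place of methoxy on an aromatic carbon gives a 1.1-fold lower number from compound 3 to compound 4 (0.04 log units; within the scatter) and so leaves the number within the scatter. Set beside the earlier case, the change carries over between these two cores with no difference that can be told apart: the same change on two cores in this assay, a 1.5-fold lower number (0.19 log units; within the scatter) from compound 2 to compound 1 and a 1.1-fold lower number (0.04 log units; within the scatter) from compound 3 to compound 4, 1.4-fold (0.14 log units) apart, within the scatter of two such steps. Within the data shown here, this shows only that the change stays small on the two cores at hand, in a series where every number lies within the scatter of the others; it does not show that methoxy at such a place never matters, it gives no direction for the change, and it says nothing of cores beyond these.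

The compounds shown leave open whether a hydroxy group, a fluorine atom or a longer chain such as ethoxy at that place would stay as close to methoxy and hydrogen. They also leave open whether replacing the remaining methoxy groups of compound 4 with hydrogen, together rather than singly, would stay within the scatter.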